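A few compounds are considered here, and "the series" means these few. Any claim that something is new, unique, unknown or untested is made for them only; others in the source may bear on it.

Compound 3 `CC1=C(C(=O)Nc2ccccc2Cl)C(c2ccc(Cl)cc2)NC(=O)N1` is recorded in an ADME assay on Vero cells (Chlorocebus sabaeus) for cytotoxicity, read by XTT assay, with a stated time of 72 h (on this read-out higher numbers stand for lower toxicity in this test and lower numbers for higher toxicity in this test), only as "non-toxic" (no number reported), without a number, so its standing is a description rather than a measured point. Two companions set the scale. Compound 1 `CC1=C(C(=O)Nc2ccc(Br)cc2)C(c2ccccc2)NC(=O)N1` gives > 100000 nM, which is a limit of the assay and not a number. Compound 2 `CC1=C(C(=O)NC2CCCCC2)C(c2ccccc2)NC(=O)N1` likewise gives > 100000 nM, again a limit. The step that the two limits leave unreadable from compound 1 to compound 2 therefore cannot be read, and the limit of > 100000 nM in this assay, at which 2 of the 3 values shown sit, is all that the measured material offers. Compound 4 `CC1=C(C(=O)Nc2ccccc2Cl)C(c2ccc(Br)cc2)NC(=O)N1` differs from compound 3 by bromo in place of chloro on an aromatic carbon. For the measured compounds named here, no measured step matches this change, so no shift beyond the scatter is expected in this assay. Compound 4 is expected to give about 150000 nM, within 60000 nM to 400000 nM, most likely reported as a limit.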

Compound 4, half-maximal cytotoxic concentration: > 100000 nM
Compound 4 was reported as a limit; the forecaster's own chance of this, stated with the estimate: 80%; the middle value does not contradict the limit.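

Compound 4 gives > 100000 nM, which is a limit. For the compounds shown here, compound 3 has only a description, so no step between the two can be read. Going by these compounds, whether bromo and chloro differ at all in this assay stays open.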